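Thioether acids in a receptor displacement assay: notes

The compounds below may be only part of what the source reports. "The series", "measured", "known", "first", "only" and "open" are said of these compounds alone.

Measured in an assay on HEK293 cells for displacement of a labelled ligand from prostaglandin D2 receptor 2 (Homo sapiens); on this read-out lower numbers stand for stronger inhibition and higher numbers for weaker inhibition:
compound 1 `O=C(O)Cn1c(SCCCOc2ccccc2)nc2ccccc21` gives 786 nM
compound 2 `O=C(O)Cn1c(SCc2ccccc2Cl)nc2ccccc21` gives 370 nM
compound 3 `COc1ccc(C)cc1CSc1nc2ccccc2n1CC(=O)O` gives 1200 nM

Compound 3 holds the highest of the three numbers in this assay. Its nearest neighbour is compound 1, whose value lies within the usual scatter of compound 3's value, so no order between these two is claimed. Compound 2 stands beyond the scatter, at a lower number than compound 3. For the measured compounds named here, no two of the measured compounds differ in one place only, so no step between measured compounds can be read off.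

Compound 4 `COc1ccc(C(=O)OC(C)C)cc1CSc1nc2ccccc2n1CC(=O)O` differs from compound 3 by isopropoxycarbonyl in place of methyl on an aromatic carbon. Going by the values given here, nothing among the measured compounds shows what an exchange of this kind does; the three values say nothing about the group at that position of the ring. The expected step is a 1.2-fold lower number from compound 3 to compound 4 (0.08 log units; within the scatter), that is, no change beyond the scatter in either direction. Among the compounds with values here, compound 4 is estimated at 1000 nM in this assay, with a range from 350 nM to 3000 nM; the range is wide, since no measured pair informs this change.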

Compound 4, half-maximal inhibitory concentration: 150 nM
Compound 4: the middle estimate sits 6.7-fold (0.82 log units) above what was measured, and the stated range ends above it.
By their numbers in this assay, from the lowest: compound 4; then compound 2; then compounds 1 and 3 (each within the scatter of the next).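

In this assay, the ring position para to the methoxy group proves sensitive to substitution: isopropoxycarbonyl in place of methyl gives an 8.0-fold lower number from compound 3 to compound 4 (0.90 log units; beyond the scatter). The earlier compounds shown here could not show this, as no two of them differ in one place only, and none carries a group other than methyl at this position. The exchange replaces a single heavy atom and no hydrogen-bond acceptors with 6 heavy atoms and 2 hydrogen-bond acceptors, so this position accepts a much larger group with a lower number on this read-out, although that rests on one pair in one assay; nothing available bears on why the number falls.

The compounds shown do not separate the contribution of the whole isopropoxycarbonyl group from that of its parts, and a methyl ester, a carboxylic acid or a primary amide at the same position would be needed to tell whether the isopropyl part matters or the carbonyl alone is enough. Also open, on these data alone, is whether the same exchange would lower the number on another member of the series, such as compound 1 or compound 2, which differ from compound 3 in more than one place.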